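Fluoro in place of bromo on the aromatic ring

A few compounds are considered here, and "the series" means these few. Any claim that something is new, unique, unknown or untested is made for them only; others in the source may bear on it.

Compound 1 `O=C(N1CCC(c2ccncc2)CC1)N1CCN(S(=O)(=O)c2ccc(Cl)cc2)CC1` in an assay for inhibition of lanosterol synthase (Rattus norvegicus), using microsomes, tested at 100 nM (on this read-out lower numbers stand for less inhibition and higher numbers for more inhibition at the one concentration tested (going by the name of the read-out)), gives 91%. Compound 2 `O=C(N1CCC(c2ccncc2)CC1)N1CCN(S(=O)(=O)c2ccc(Br)cc2)CC1` in this assay gives 94%. The step of a number 3 percentage points higher from compound 1 to compound 2 (within the scatter) is within the scatter, so compound 2 and compound 1 give numbers that cannot be told apart on this read-out; compound 2 stands at the same level as compound 1 rather than above it.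

Compound 3 `O=C(N1CCC(c2ccncc2)CC1)N1CCN(S(=O)(=O)c2ccc(F)cc2)CC1` differs from compound 2 by fluoro in place of bromo on an aromatic carbon. Within the data shown here, the one measured step that bears on this change is the halogen exchange from compound 1 to compound 2, which stayed within the scatter. On that basis no step beyond the scatter is expected here either, and a number 8 percentage points lower from compound 2 to compound 3 (within the scatter) is the estimated change from compound 2 to compound 3. In this assay compound 3 is therefore expected to give 86%, within a range of 70% to 96%.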

Compound 3, a percentage reported as inhibition, at one concentration (the size of the read-out at that concentration, not a potency): 97%
Estimate against measurement, compound 3: 11 percentage points below; the whole stated range lies below it.
By their numbers in this assay, from the lowest: compounds 1, 2 and 3 (each within the scatter of the next).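

In this assay, fluoro in place of bromo gives a number 3 percentage points higher from compound 2 to compound 3 (within the scatter), and fluoro in place of chloro gives a number 6 percentage points higher from compound 1 to compound 3 (within the scatter). The earlier pair covered only chloro and bromo; with fluoro added, three halogens at this aromatic carbon give numbers that cannot be told apart on this read-out at the one concentration tested. Nothing available explains this lack of separation.

Open, on these data alone, is whether a group other than a halogen on this carbon, such as methoxy, an amine or a carboxylic acid, would give a number that stands apart from these three. Also open, as far as these compounds go, are whether the three halogen compounds would separate at a lower concentration and how changes elsewhere on the shared core would read.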